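The source may report more compounds than this note shows. Statements on the series, on what has been measured and on what is new or still open speak of the compounds shown alone.

Measured compounds in an assay on mitochondria from L6 cells (Rattus norvegicus) for activation, with a stated time of 90 min; a higher number here means that more compound is needed for the effect, a lower number that less compound is needed:
compound 1 `Oc1nc2nonc2nc1Nc1cccc(F)c1` — 31200 nM
compound 2 `Oc1nc2nonc2nc1Nc1ccc(C(F)(F)F)cc1` — 10400 nM

Compound 2 holds the lower of the two numbers in this assay; the gap to compound 1 lies beyond the scatter. Going by the values given here, no pair of measured compounds differs in one place, so nothing shows how a single change moves this assay.

Compound 3 `Oc1nc2nonc2nc1Nc1ccc(C(F)(F)F)c(F)c1` differs from compound 2 by fluoro in place of hydrogen on an aromatic carbon. Among the compounds with values here, with no comparable step among the measured pairs, a change of about this size is expected to stay within the scatter, in either direction. Compound 3 is expected to give 9000 nM, between 3500 nM and 25000 nM. This estimate means an expected step of a 1.2-fold lower number from compound 2 to compound 3 (0.06 log units; within the scatter), within the scatter.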

Compound 3, half-maximal effective concentration: 11600 nM
Beside the measured number, compound 3's estimate is 1.3-fold (0.11 log units) below it; low and high end bracket the measured number.
By their numbers in this assay, from the lowest: compounds 2 and 3 (each within the scatter of the next); then compound 1.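

Fluoro on the aromatic carbon ortho to a trifluoromethyl group is tolerated in this assay (a 1.1-fold higher number from compound 2 to compound 3 (0.05 log units; within the scatter)), so this position accepts that added atom without a step beyond the scatter. Trifluoromethyl in place of hydrogen gives the first single change that goes beyond the scatter (a 2.7-fold lower number from compound 1 to compound 3 (0.43 log units; beyond the scatter)), though the step is modest. Nothing available explains the size of either step. Still open, on these data alone, is whether a larger or different group at this position, such as methoxy, an amine or a carboxylic acid, would move the number beyond the scatter.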